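Same Atoms, Different Join: a Methyl Moved on a Ring

This account rests on a few compounds, and the source may have more. Where it says the series, first, only, none or still open, it means among the compounds named here.

Compound 1 `Cc1ccccc1Nc1nc(C)c(C(=O)/C=C/c2ccc(Cl)cc2)s1` and compound 3 `Cc1cccc(Nc2nc(C)c(C(=O)/C=C/c3ccc(Cl)cc3)s2)c1` share one core; compound 2 `COc1cc(/C=C/C(=O)c2sc(Nc3ccccc3C)nc2C)cc(OC)c1OC` and compound 4 `COc1cc(/C=C/C(=O)c2sc(Nc3cccc(C)c3)nc2C)cc(OC)c1OC` share another, and the difference between the two cores is not broken down here. In a functional assay on PC-3 cells (Homo sapiens) for cytotoxicity, read by MTT assay (a lower number here means a stronger inhibitor, a higher number a weaker inhibitor), compound 1 gives only a limit, > 25000 nM. Compound 3 likewise gives a limit in this assay, > 25000 nM. Compound 2 too reaches only a limit in this assay, > 25000 nM. Compound 3 differs from compound 1 by 3-methylphenyl in place of 2-methylphenyl on a nitrogen on an aromatic ring, and the step that the two limits leave unreadable from compound 1 to compound 3 cannot be read because of the limit of > 25000 nM in this assay, at which 3 of the 3 values shown sit. Compound 4 differs from compound 2 by the same change, (3-methylphenyl in place of 2-methylphenyl on a nitrogen on an aromatic ring). With the measured step unreadable, the step from compound 2 to compound 4 is expected to be a step that the limit leaves unreadable from compound 2 to compound 4, the value most likely staying at a limit. Compound 4 is therefore estimated at 40000 nM, between 15000 nM and 150000 nM.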

Compound 4, half-maximal inhibitory concentration: > 25000 nM
Compound 4 was reported as a limit (the forecaster's own chance of this, stated with the estimate: 85%); the middle value is on the limit's open side.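

No size can be read for the step between compound 2 and compound 4, as each gives only a limit: the limit of > 25000 nM in this assay, at which 4 of the 4 values shown sit.

The compounds shown leave open how 2-methylphenyl and 3-methylphenyl truly compare in this assay, on either core.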